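The source may hold more compounds than are shown below. What is called first, only, known or untested is meant among the compounds shown, and "the series" means these compounds.

Measured so far, in an ADME assay on MT2 cells (Homo sapiens) for cytotoxicity; a higher number here means that more compound is tolerated, a lower number that less compound is tolerated:

Compound 1 `COc1cc(CNC(=O)c2cc3nc(C)c([C@H](OC(C)(C)C)C(=O)O)c(-c4cc(F)c5c(c4C)CCCO5)n3n2)ccc1F` gives > 20000 nM in this assay, and this is a limit of the assay rather than a number. Compound 2 `CNC(=O)c1cc(F)ccc1CNC(=O)c1cc2nc(C)c([C@H](OC(C)(C)C)C(=O)O)c(-c3cc(F)c4c(c3C)CCCO4)n2n1` gives > 40000 nM in this assay, again a limit rather than a number.

Compound 2 therefore stands at one of two limits; the other value shown is a limit too, and the step that the two limits leave unreadable from compound 1 to compound 2 cannot be read from them. The untested compound 3 `Cc1nc2cc(C(=O)NCC3CCCCC3)nn2c(-c2cc(F)c3c(c2C)CCCO3)c1[C@H](OC(C)(C)C)C(=O)O` differs from compound 2 in one place: cyclohexyl in place of 4-fluoro-2-(methylcarbamoyl)phenyl on a saturated chain carbon bound to an amide-type nitrogen. Going by the values given here, no measured step tells how much this kind of exchange changes tolerance in this assay, since the only step available is the unreadable one from compound 1 to compound 2, whose ends sit at the limit of > 20000 nM in this assay, at which 1 of the 2 values shown sits, and (the limit of > 40000 nM in this assay, at which 1 of the 2 values shown sits). The expectation is therefore that compound 3 is also tolerated up to a limit, so the step of an at least 1.3-fold lower number from compound 2 to compound 3 (0.12 log units; that floor lies within the scatter) is expected to be small or not readable. For compound 3 an estimate of 30000 nM is given, within 10000 nM to 100000 nM.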

Compound 3, half-maximal cytotoxic concentration: > 40000 nM
Compound 3: only a limit was reported (the forecaster's own chance of this, stated with the estimate: 70%); at least 1.3-fold (0.12 log units) between middle value and limit.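

In this assay compound 3 gives > 40000 nM, which is again a limit and not a number. Going by these compounds alone, no step among compound 1, compound 2 and compound 3 can therefore be read. Going by these compounds, the concentration at which any of these three compounds reaches its half-maximal cytotoxic effect remains open.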